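A few compounds are considered here, and "the series" means these few. Any claim that something is new, unique, unknown or untested is made for them only; others in the source may bear on it.

Working notes on the series, read in a functional assay on MCF7 cells (Homo sapiens) for antiproliferative activity, read by MTT assay, with a stated time of 48 h; a higher number here means a weaker inhibitor, a lower number a stronger inhibitor. Compound 1 (`COc1cc2ncnc(Nc3cccc(Br)c3)c2cc1OCCCC(=O)NO`) gives 68400 nM. Compound 2 (`COc1cc2ncnc(Nc3ccc(Cl)cc3Cl)c2cc1OCCC(=O)NO`) gives 95000 nM, which lies within the scatter of the value for compound 1, so the two stand in the same range and no order can be drawn between them.

Compound 3 (`COc1cc2ncnc(Nc3ccc(Cl)cc3Cl)c2cc1OCCCC(=O)NO`) takes compound 2 from the 2-(hydroxycarbamoyl)ethoxy chain to the 3-(hydroxycarbamoyl)propoxy chain: (hydroxycarbamoyl)methyl in place of hydroxycarbamoyl on a saturated chain carbon, two bonds along the chain from an oxygen on an aromatic ring. Among the measured compounds shown here, no measured pair shows this change alone. For the measured compounds named here, the only reading on the longer chain comes from compound 1, at 68400 nM, so no change beyond the scatter is expected in this assay, with at most a slight drift towards a lower number. The estimated change is a 1.5-fold lower number from compound 2 to compound 3 (0.16 log units; within the scatter), expected to stay within the scatter. For compound 3 the expected value is 65000 nM, with an estimated range of 28000 nM to 130000 nM.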

Compound 3, half-maximal inhibitory concentration: 56800 nM
Estimate against measurement, compound 3: 1.1-fold (0.06 log units) above; the measured number falls inside the stated range.
By their numbers in this assay, from the lowest: compounds 3, 1 and 2 (each within the scatter of the next).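

In this assay the chain change can now be read alone: (hydroxycarbamoyl)methyl in place of hydroxycarbamoyl on a saturated chain carbon, two bonds along the chain from an oxygen on an aromatic ring, gives a 1.7-fold lower number from compound 2 to compound 3 (0.22 log units; within the scatter) with the 2,4-dichlorophenyl group held constant. On the 3-(hydroxycarbamoyl)propoxy chain, the aromatic group can also be read alone: 2,4-dichlorophenyl in place of 3-bromophenyl on a nitrogen on an aromatic ring gives a 1.2-fold lower number from compound 1 to compound 3 (0.08 log units; within the scatter) and neither change separates the compounds. No supporting measurement accounts for either step.

From the compounds shown here alone, whether a longer chain such as 4-(hydroxycarbamoyl)butoxy would move the number beyond the scatter remains open. So does the effect of a carboxylic acid in place of the hydroxycarbamoyl group at the chain end.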